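Working notes on a short cytotoxicity series

The compounds below may be only part of what the source reports. "The series", "measured", "known", "first", "only" and "open" are said of these compounds alone.

Measured compounds:
Compound 1 `FC(F)(F)C(F)(F)C(F)(F)C(F)(F)C(F)(F)C(F)(F)CCn1cc(COc2ccccc2-c2nc3ccccc3s2)nn1` — in a functional assay on A549 cells (Homo sapiens) for cytotoxicity, read by MTT assay, with a stated time of 24 h (a higher number here means a weaker inhibitor, a lower number a stronger inhibitor), compound 1 gives 15100 nM
Compound 2 `FC(F)(F)Oc1ccc(-c2cc(COc3ccccc3-c3nc4ccccc4s3)on2)cc1` — compound 2 gives 23900 nM
Compound 3 `Brc1ccc(-c2cc(COc3ccccc3-c3nc4ccccc4s3)on2)cc1` — compound 3 gives 19200 nM

Compound 3 holds the second highest of the three numbers, but its gaps to compound 2 and to compound 1 both lie within the scatter, so no ranking among the three can be stated. Compound 4 `Fc1ccccc1-c1cc(COc2ccccc2-c2nc3ccccc3s2)on1` differs from compound 3 by 2-fluorophenyl in place of 4-bromophenyl on an aromatic carbon. Among the measured compounds shown here, the only measured step on this same aryl group is a 1.2-fold lower number from compound 2 to compound 3 (0.10 log units; within the scatter), which stayed within the scatter. For the measured compounds named here, no measured pair exchanges 4-bromophenyl for 2-fluorophenyl, so the size of that change is not known from this series. Going by the values given here, on the one small step available, compound 4 is expected to show a 1.0-fold lower number from compound 3 to compound 4 (0.00 log units; within the scatter), nothing beyond the scatter. Compound 4 is therefore estimated at 19000 nM, with a range from 8000 nM to 45000 nM.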

Compound 4, half-maximal inhibitory concentration: 22500 nM
Compound 4: the middle estimate sits 1.2-fold (0.07 log units) below what was measured; the range from low to high includes it.
By their numbers in this assay, from the lowest: compounds 1, 3, 4 and 2 (each within the scatter of the next).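

In this assay, 2-fluorophenyl in place of 4-bromophenyl on the carbon next to the ring nitrogen gives a 1.2-fold higher number from compound 3 to compound 4 (0.07 log units; within the scatter), and in place of 4-(trifluoromethoxy)phenyl it gives a 1.1-fold lower number from compound 2 to compound 4 (0.03 log units; within the scatter). Three different aryl groups at this position, including one with fluorine named at the 2-position rather than a group at the 4-position, therefore cannot be told apart by this read-out. No evidence bears on this result.

From the compounds shown here alone, whether an amine or a carboxylic acid on the phenyl ring would move the number beyond the scatter remains open. The same holds for a simple butyl chain in place of the aryl group.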